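The compounds below may be only part of what the source reports. "The series", "measured", "known", "first", "only" and "open" are said of these compounds alone.

Measured in a functional assay on MCF7 cells (Homo sapiens) for antiproliferative activity, read by sulforhodamine B assay, with a stated time of 72 h; a higher number here means a weaker inhibitor, a lower number a stronger inhibitor:
Compound 1 `O=C1C=CCC/C1=C\c1ccc(OC(F)(F)F)cc1`: 1040 nM
Compound 2 `COc1ccc(/C=C2\CCC=CC2=O)c(C)c1`: 1840 nM
Compound 3 `COc1cc(/C=C2\CN(C(=O)OCc3ccccc3)C=CC2=O)cc(OC)c1OC`: > 25000 nM

For compound 3, the entry > 25000 nM is a limit and not a number. Compound 4 `COc1cc(/C=C2\CN(S(C)(=O)=O)C=CC2=O)cc(OC)c1OC` carries methylsulfonyl in place of benzyloxycarbonyl on an amine nitrogen in a ring.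

For the measured compounds named here, no measured step covers this change, so the expectation is loose. Going by the values given here, the only numerical readings are for compound 1 at 1040 nM and compound 2 at 1840 nM. These leave room for a numerical result, although compound 4 may also stay at the limit in this assay. The expected at least 2.5-fold lower number from compound 3 to compound 4 (0.39 log units; beyond the scatter) is a moderate one toward stronger inhibition. For compound 4 the expected value is 10000 nM, with an estimated range of 2500 nM to 40000 nM.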

Compound 4, half-maximal inhibitory concentration: 17600 nM
Beside the measured number, compound 4's estimate is 1.8-fold (0.25 log units) below it, and the stated range covers the measured number.
By their numbers in this assay, from the lowest: compounds 1 and 2 (each within the scatter of the next); then compound 4. At a limit, above all of these: compound 3.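

On the amine nitrogen in a ring, methylsulfonyl in place of benzyloxycarbonyl gives a numerical reading at this position in this assay: compound 4 at 17600 nM. The change reads as an at least 1.4-fold lower number from compound 3 to compound 4 (0.15 log units; that floor lies within the scatter), so a real gain is not established. Compound 3 stands at a limit, so this step is only a floor: the limit of > 25000 nM in this assay, at which 1 of the 4 values shown sits.

As far as these compounds go, whether an acetyl, an ethyl chain or an unsubstituted ring nitrogen would shift the number further remains open. Compound 1 and compound 2 differ from compound 4 in more than one place, so they cannot show what the ring nitrogen contributes.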